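Alpha-methyl on the acid chain of compound 1

The source may hold more compounds than are shown below. What is called first, only, known or untested is meant among the compounds shown, and "the series" means these compounds.

Compound 1 `Cc1cccc(C)c1-c1cccc(COc2ccc(CCC(=O)O)cn2)c1` gives the lowest number of the three measured compounds in a functional assay on CHO cells for agonist activity at Free fatty acid receptor 1 (Homo sapiens), read by calcium flux (a lower number here means that less compound is needed, a higher number that more compound is needed for the effect), at 3.5 nM. Compound 2 `Cc1cccc(C)c1-c1cccc(COc2ccc(CCC(=O)O)c(C)n2)c1` gives 81 nM in this assay, and compound 3 `Cc1cc(CCC(=O)O)cnc1OCc1cccc(-c2c(C)cccc2C)c1` gives 2500 nM. Both steps from compound 1 place a methyl on an aromatic carbon: a 23-fold higher number from compound 1 to compound 2 (1.36 log units; beyond the scatter) and a 710-fold higher number from compound 1 to compound 3 (2.85 log units; beyond the scatter), each large and beyond the scatter.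

Compound 4 `Cc1cccc(C)c1-c1cccc(COc2ccc(CC(C)C(=O)O)cn2)c1` differs from compound 1 by methyl in place of hydrogen on a saturated chain carbon bound to a carbonyl carbon and a saturated chain carbon. Within the data shown here, no measured step puts a methyl on the saturated chain, so the two aromatic-methyl steps bear on it only loosely; they show that a methyl added to compound 1 has so far only raised the number, but at places unlike this one. A small loss is therefore expected for compound 4, amounting to a 2.6-fold higher number from compound 1 to compound 4 (0.41 log units; beyond the scatter), smaller than either measured step. Compound 4 is estimated at 9 nM in this assay, within a range from 2.5 nM to 40 nM.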

Compound 4, half-maximal effective concentration: 65 nM
Beside the measured number, compound 4's estimate is 7.2-fold (0.86 log units) below it; the measured number lies above the stated range.
By their numbers in this assay, from the lowest: compound 1; then compounds 4 and 2 (each within the scatter of the next); then compound 3.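

The step of a 19-fold higher number from compound 1 to compound 4 (1.27 log units; beyond the scatter) shows that the saturated chain carbon bound to a carbonyl carbon and a saturated chain carbon is also a place where a single methyl carries a large cost in this assay. The loss from adding a methyl to compound 1 is therefore not confined to aromatic carbons. All three single methyl additions shown now raise the number by a large step, and no compound shown goes against this, but nothing available explains the rise at this carbon.

What the compounds shown leave open is whether the cost belongs to methyl alone or to any group at this carbon. On these data alone, a fluorine, a hydroxyl or an ethyl there could give a quite different number, and the same carbon carrying two methyl groups also remains untested among them.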